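The source may hold more compounds than are shown below. What is called first, only, known or untested is meant among the compounds shown, and "the series" means these compounds.

Among the measured compounds shown here, compound 3 `O=C1c2ccccc2S(=O)(=O)N1CCCCCCN1CCN(c2cccc(Cl)c2Cl)CC1` gives 119 nM in an ADME assay on HEK293 cells for displacement of a labelled ligand from 5-hydroxytryptamine receptor 7 (Homo sapiens), read by radioligand binding, with a stated time of 1 h (a lower number here means a stronger inhibitor, a higher number a weaker inhibitor), the lowest of the three numbers so far. Compound 1 `O=C1c2ccccc2S(=O)(=O)N1CCCCCCN1CCN(c2ccccc2Cl)CC1` gives 120 nM in this assay, and the step of a 1.0-fold lower number from compound 1 to compound 3 (0.00 log units; within the scatter) lies within the scatter, so these two cannot be ordered. Compound 2 `O=C1c2ccccc2S(=O)(=O)N1CCCCCCN1CCN(c2ccccc2F)CC1` gives 322 nM in this assay, and the steps of a 2.7-fold higher number from compound 1 to compound 2 (0.43 log units; beyond the scatter) and a 2.7-fold lower number from compound 2 to compound 3 (0.43 log units; beyond the scatter) are modest. Compound 4 `O=C1c2ccccc2S(=O)(=O)N1CCCCCCN1CCN(c2cccc(C(F)(F)F)c2)CC1` is the next candidate, and the change is 3-(trifluoromethyl)phenyl in place of 2,3-dichlorophenyl on an amine nitrogen in a ring. For the measured compounds named here, no measured step swaps the whole aryl group in this way, and the substituent steps seen were all modest. For compound 4 a modest shift toward a higher number is therefore expected, a 2.5-fold higher number from compound 3 to compound 4 (0.40 log units; beyond the scatter). Compound 4 is estimated at 300 nM, with a range of 100 nM to 1000 nM.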

Compound 4, inhibition constant: 58 nM
For compound 4 the middle estimate is 5.2-fold (0.71 log units) above the measured one; measured number outside the range, below it.
By their numbers in this assay, from the lowest: compound 4; then compounds 3 and 1 (each within the scatter of the next); then compound 2.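

In this assay the aryl group on the ring amine nitrogen accepts 3-(trifluoromethyl)phenyl, with a 2.1-fold lower number from compound 3 to compound 4 (0.31 log units; beyond the scatter) and a 2.1-fold lower number from compound 1 to compound 4 (0.32 log units; beyond the scatter) and a 5.6-fold lower number from compound 2 to compound 4 (0.74 log units; beyond the scatter) all modest and all in the same direction. Compound 4 therefore has the lowest number of the four, so a group with neither chloro nor fluoro directly on the aromatic ring goes lower than those earlier aryl groups. Nothing available explains this drop. Going by these compounds, whether a methoxy or nitrile group in place of trifluoromethyl would hold this gain remains open, as does the effect of a longer chain on compound 4.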